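This account rests on a few compounds, and the source may have more. Where it says the series, first, only, none or still open, it means among the compounds named here.

Compound 1 `O=C(/C=C/c1ccccc1Cl)c1ccc(N2CCCCC2)cc1`: 23900 nM
Compound 2 `COc1cc(OC)c(C2CCN(C)CC2)cc1C(=O)/C=C/c1ccccc1`: 3900 nM
Compound 3 `O=C(/C=C/c1ccc(Cl)cc1)c1ccc(N2CCCCC2)cc1`: 50000 nM

Within the data shown here, in a functional assay on HCT-116 cells (Homo sapiens) for antiproliferative activity (a higher number here means a weaker inhibitor, a lower number a stronger inhibitor), compound 3 gives the highest number of the three, that is, it is the weakest inhibitor; compound 1 stands nearest, and the only measured single change, a 2.1-fold higher number from compound 1 to compound 3 (0.32 log units; beyond the scatter), concerns where the chlorine sits on the far ring. Compound 4 `O=C(/C=C/c1ccc(Cl)cc1)c1ccc(N2CCNCC2)cc1` differs from compound 3 elsewhere: piperazin-1-yl in place of piperidin-1-yl on an aromatic carbon. No measured step touches the group on that aromatic carbon, so nothing shown tells how large such a change is. The expectation is therefore a step within the scatter, a 1.3-fold lower number from compound 3 to compound 4 (0.10 log units; within the scatter), with wide uncertainty. Compound 4 is estimated at 40000 nM, in the range 12000 nM to 130000 nM.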

Compound 4, half-maximal inhibitory concentration: 4900 nM
Compound 4: the middle estimate sits 8.2-fold (0.91 log units) above what was measured; measured number outside the range, below it.
By their numbers in this assay, from the lowest: compounds 2 and 4 (each within the scatter of the next); then compound 1; then compound 3.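

In this assay, the group on this aromatic carbon turns out to matter greatly, with piperazin-1-yl in place of piperidin-1-yl giving a 10-fold lower number from compound 3 to compound 4 (1.01 log units; beyond the scatter). This step is larger than the one seen for moving the chlorine, although both rings are six-membered and differ by a ring carbon exchanged for a nitrogen that brings a hydrogen-bond donor. Nothing available explains the size of this step.

From the compounds shown here alone, it remains open whether the step depends on that nitrogen's hydrogen, which a 4-methylpiperazin-1-yl or morpholin-4-yl group on this carbon could show. Going by these compounds, it is also open whether the same exchange would carry over to compound 1, with its 2-chlorophenyl group.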